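The source may report more compounds than this note shows. Statements on the series, on what has been measured and on what is new or still open speak of the compounds shown alone.

Working notes on the series. Compound 1 `O=C(c1ccc([N+](=O)[O-])cc1)N1CCC(n2cncc2-c2ccc(OS(=O)(=O)c3cccc4cnccc34)cc2)CC1` is defined by the nitro group on the amide aryl ring and an isoquinolinyl sulfonate; in an assay on HEK293 cells for antagonist activity at P2X purinoceptor 7 (Homo sapiens), read by fluorescence, with a stated time of 2 h (on this read-out higher numbers stand for weaker inhibition and lower numbers for stronger inhibition), compound 1 gives 1.49 nM, the lower of the two numbers recorded so far. For the measured compounds named here, compound 2 `CCN(CC)c1ccc(C(=O)N2CCC(n3cncc3-c3ccc(OS(=O)(=O)c4cccc5cnccc45)cc3)CC2)cc1` differs from it only at the amide aryl ring, and in this assay compound 2 gives 1440 nM; the step of a 970-fold higher number from compound 1 to compound 2 (2.99 log units; beyond the scatter) is the only measured step in the set. Compound 3 `O=C(NC1CC1)c1cccc(S(=O)(=O)Oc2ccc(-c3cncn3C3CCN(C(=O)c4ccc([N+](=O)[O-])cc4)CC3)cc2)c1` keeps the nitro group of compound 1 and alters the sulfonate instead: 3-(cyclopropylcarbamoyl)phenyl in place of isoquinolin-5-yl on a sulfonyl sulfur. Going by the values given here, no measured step touches the sulfonate aryl group, so the step from compound 1 to compound 2 does not bear on this change and gives no guide to its size or direction. With no data at that position, a modest weakening is taken as the default expectation, with wide uncertainty. Compound 3 is therefore expected to give about 5 nM, within a range of 1 nM to 30 nM, which would mean an expected step of a 3.4-fold higher number from compound 1 to compound 3 (0.53 log units; beyond the scatter).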

Compound 3, half-maximal inhibitory concentration: 152 nM
Compound 3: the middle estimate sits 30-fold (1.48 log units) below what was measured; measured number outside the range, above it.
By their numbers in this assay, from the lowest: compound 1; then compound 3; then compound 2.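

With the nitro group kept, 3-(cyclopropylcarbamoyl)phenyl in place of isoquinolin-5-yl on a sulfonyl sulfur gives a 100-fold higher number from compound 1 to compound 3 (2.01 log units; beyond the scatter) (this assay), so this position is a second place where a single change moves the number well beyond the scatter. The nitro group therefore does not by itself secure the low number of compound 1; the group on the sulfonyl sulfur counts as well. Nothing available here bears on why this change has so large an effect.

The compounds shown leave open which part of the change carries the step: the loss of the isoquinolin-5-yl group or the arrival of the cyclopropylcarbamoyl group. A plain phenyl or a naphthyl group on the sulfonyl sulfur would help separate the two.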